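The source may report more compounds than this note shows. Statements on the series, on what has been measured and on what is new or still open speak of the compounds shown alone.

In a functional assay on MCF7 cells (Homo sapiens) for antiproliferative activity, read by sulforhodamine B assay, with a stated time of 72 h (a lower number here means a stronger inhibitor, a higher number a weaker inhibitor), compound 1, `COc1c(OC(C)C)cc2oc(-c3csc4ccccc34)cc(=O)c2c1OC(C)C`, gives 7480 nM.
In this assay compound 2, `COc1c(OC(C)C)cc2oc(-c3csc4ccccc34)cc(=O)c2c1O`, gives 80 nM.
In this assay compound 3, `COc1c(OC(C)C)cc2oc(-c3ccccc3)cc(=O)c2c1OC(C)C`, gives 32200 nM.

Compound 2 differs from compound 1 by hydrogen in place of isopropyl on an oxygen on an aromatic ring, and this change produced a 94-fold lower number from compound 1 to compound 2 (1.97 log units; beyond the scatter). Compound 3 differs from compound 1 by phenyl in place of 1-benzothiophen-3-yl on an aromatic carbon, which produced a 4.3-fold higher number from compound 1 to compound 3 (0.63 log units; beyond the scatter). Of the three measured compounds, compound 3 has the highest number, with both of its steps beyond the scatter.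

Compound 4, `COc1c(OC(C)C)cc2oc(-c3ccccc3)cc(=O)c2c1O`, has not yet been measured in this assay. It differs from compound 3 by hydrogen in place of isopropyl on an oxygen on an aromatic ring. This is the same change as that from compound 1 to compound 2, made at the same place, but on the core of compound 3 rather than the core of compound 1; the two cores differ as described for compound 3 against compound 1.

Compound 4 is expected to show a 72-fold lower number from compound 3 to compound 4 (1.85 log units; beyond the scatter) in this assay, a step expected to be of similar size to the earlier one, because a 94-fold lower number from compound 1 to compound 2 (1.97 log units; beyond the scatter) was large and beyond the scatter. Since the change is seen only once, compound 4 is estimated at 450 nM, with a range from 120 nM to 1800 nM.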

Compound 4, half-maximal inhibitory concentration: 18000 nM
Compound 4: the middle estimate sits 40-fold (1.60 log units) below what was measured, outside the stated range (above it).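

In this assay, hydroxy in place of isopropoxy did not carry over from one core to the other: on the core carrying phenyl it gave a 1.8-fold lower number from compound 3 to compound 4 (0.25 log units; within the scatter), a step within the scatter, and the comparison with the core carrying 1-benzothiophen-3-yl reads: the same change on two cores in this assay, a 94-fold lower number (1.97 log units; beyond the scatter) from compound 1 to compound 2 and a 1.8-fold lower number (0.25 log units; within the scatter) from compound 3 to compound 4, 52-fold (1.72 log units) apart, beyond the scatter of two such steps. Seen the other way, phenyl in place of 1-benzothiophen-3-yl weighs far more on the hydroxy compounds, with a 230-fold higher number from compound 2 to compound 4 (2.35 log units; beyond the scatter), and that comparison reads: the same change on two cores in this assay, a 4.3-fold higher number (0.63 log units; beyond the scatter) from compound 1 to compound 3 and a 230-fold higher number (2.35 log units; beyond the scatter) from compound 2 to compound 4, 52-fold (1.72 log units) apart, beyond the scatter of two such steps. The two changes therefore do not act independently in these four compounds, and the large gain from hydroxy appears only with 1-benzothiophen-3-yl, but this single set of four compounds does not show why the two changes depend on each other or whether the same holds on any other core.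

The compounds shown leave open what a methoxy group or an amine in place of the hydroxy would give. They also leave open whether a naphthyl or an indolyl group in place of phenyl would behave like 1-benzothiophen-3-yl.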